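The compounds below may be only part of what the source reports. "The series", "measured", "known", "first", "only" and "open" are said of these compounds alone.

Compound 3 `Cc1oncc1-c1cccc2c1CCC2c1ncc[nH]1` shares its core with two companions. In a functional assay on CHO cells for agonist activity at Alpha-1D adrenergic receptor (Homo sapiens), read by FLIPR and calcium flux (a higher number here means that more compound is needed for the effect, a lower number that less compound is needed), compound 3 gives only a limit, > 10000 nM. Compound 1 `CCCS(=O)(=O)Nc1cccc2c1CCC2c1ncc[nH]1` likewise reaches only a limit in this assay, > 10000 nM. Compound 2 `c1cncc(-c2cccc3c2CCC3c2ncc[nH]2)c1` also stops at a limit in this assay, > 10000 nM. All three values sit together at the limit of > 10000 nM in this assay, at which 3 of the 3 values shown sit. Compound 4 `c1cc(-c2cn[nH]c2)c2c(c1)C(c1ncc[nH]1)CC2` differs from compound 3 by 1H-pyrazol-4-yl in place of 5-methyl-1,2-oxazol-4-yl on an aromatic carbon. Within the data shown here, the steps that bear on this exchange are a step that the two limits leave unreadable from compound 1 to compound 2, a step that the two limits leave unreadable from compound 1 to compound 3 and a step that the two limits leave unreadable from compound 2 to compound 3, and none of them yields a readable size, so no step of any direction can be foreseen beyond a further limit. Compound 4 is therefore expected to give about 15000 nM, between 5000 nM and 50000 nM, in this assay, most likely again as a limit, which means an expected step that the limit leaves unreadable from compound 3 to compound 4.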

Compound 4, half-maximal effective concentration: 319 nM
The estimate for compound 4 lay 47-fold (1.67 log units) above the measured number; the whole stated range lies above it.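

In this assay, the group on this aromatic carbon decides whether a number can be read at all, and compound 4 alone comes clear of the shared limit: the limit of > 10000 nM in this assay, at which 3 of the 4 values shown sit. Exchange for 1H-pyrazol-4-yl gives an at least 31-fold lower number from compound 3 to compound 4 (1.49 log units; beyond the scatter), and likewise an at least 31-fold lower number from compound 2 to compound 4 (1.49 log units; beyond the scatter) and an at least 31-fold lower number from compound 1 to compound 4 (1.49 log units; beyond the scatter). A five-membered aromatic ring with 2 hetero atoms is not enough by itself, since compound 3 carries one and remains at a limit.

The steps among compound 1, compound 2 and compound 3 cannot be read. On these data alone, whether the lower number survives a methyl group on the pyrazole ring nitrogen, or whether an amine or a carboxylic acid on this carbon also gives a readable value, stays open.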